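This account rests on a few compounds, and the source may have more. Where it says the series, first, only, none or still open, it means among the compounds named here.

Three compounds share one core and differ only in the group carried on a saturated chain carbon bound to an amide-type nitrogen. Compound 1 `CCC(NC(=O)C(CC(C)C)NC(=O)OCc1ccccc1)C(=O)C(=O)NCC1CCCCC1` gives 680 nM in an assay on isolated protein for inhibition of Calpain-1 catalytic subunit (Homo sapiens); a lower number here means a stronger inhibitor, a higher number a weaker inhibitor. Compound 2 `CCC(NC(=O)C(CC(C)C)NC(=O)OCc1ccccc1)C(=O)C(=O)NCc1cc(OC)cc(OC)c1` gives 2300 nM in this assay, and compound 3 `CCC(NC(=O)C(CC(C)C)NC(=O)OCc1ccccc1)C(=O)C(=O)NCc1ccc2ccccc2n1` gives 130 nM in this assay. Compound 3 stands lowest of the three measured numbers: a 5.2-fold lower number from compound 1 to compound 3 (0.72 log units; beyond the scatter), an 18-fold lower number from compound 2 to compound 3 (1.25 log units; beyond the scatter), while a 3.4-fold higher number from compound 1 to compound 2 (0.53 log units; beyond the scatter). Compound 4 `CCC(NC(=O)C(CC(C)C)NC(=O)OCc1ccccc1)C(=O)C(=O)NCCCN1CCc2ccccc2C1` differs from compound 3 by 2-(1,2,3,4-tetrahydroisoquinolin-2-yl)ethyl in place of quinolin-2-yl on a saturated chain carbon bound to an amide-type nitrogen. For the measured compounds named here, no measured step makes this exact exchange; the three steps show only that changing the group at this place moves the number in this assay by modest to large amounts, and that among the three groups tried quinolin-2-yl gives the lowest number. An upward step in this assay is therefore expected, of a size comparable to a 5.2-fold lower number from compound 1 to compound 3 (0.72 log units; beyond the scatter) run in reverse. Compound 4 is estimated at 600 nM, with a range from 150 nM to 2500 nM, so the expected step is a 4.6-fold higher number from compound 3 to compound 4 (0.66 log units; beyond the scatter).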

Compound 4, inhibition constant: 310 nM
Estimate against measurement, compound 4: 1.9-fold (0.29 log units) above; the measured number falls inside the stated range.
By their numbers in this assay, from the lowest: compound 3; then compound 4; then compound 1; then compound 2.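

In this assay, the 2-(1,2,3,4-tetrahydroisoquinolin-2-yl)ethyl group gives a lower number than two of the earlier groups at this place, with a 2.2-fold lower number from compound 1 to compound 4 (0.34 log units; beyond the scatter) and a 7.4-fold lower number from compound 2 to compound 4 (0.87 log units; beyond the scatter). It does not match quinolin-2-yl, however, with a 2.4-fold higher number from compound 3 to compound 4 (0.38 log units; beyond the scatter), so compound 3 keeps the lowest number of the four. An aromatic ring in the group does not by itself set the order: compound 3, compound 4 and compound 2 all carry one, yet compound 1, whose cyclohexyl has none, falls among them.

Nothing available here explains these differences between the groups. On these data alone, what a morpholine on the same chain or an unsubstituted phenyl at this place would give stays open.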